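Replacing an oxazole with a methylpiperazine side chain

This account rests on a few compounds, and the source may have more. Where it says the series, first, only, none or still open, it means among the compounds named here.

Three related compounds frame this step: compound 1 (`COc1c(OCCCCNCc2ccccc2)cc(O)c2c(=O)cc(-c3ccccc3)oc12`), compound 2 (`COc1c(OCc2ncc(C)o2)cc(O)c2c(=O)cc(-c3ccccc3)oc12`) and compound 3 (`O=c1cc(-c2ccccc2)oc2c(OCCNCCO)c(O)cc(O)c12`). In a functional assay on A549 cells (Homo sapiens) for cytotoxicity, read by MTT assay, with a stated time of 48 h (a lower number here means a stronger inhibitor, a higher number a weaker inhibitor), compound 1 gives 4590 nM as its measured value. Compound 2 gives > 100000 nM and this is a limit of the assay, not a number. Compound 3 has the entry "not determined" (no result reported) and so offers no guidance.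

The change from compound 2 to compound 4 (`COc1c(OCCCN2CCN(C)CC2)cc(O)c2c(=O)cc(-c3ccccc3)oc12`) sits on a saturated chain carbon bound to an oxygen on an aromatic ring, and 2-(4-methylpiperazin-1-yl)ethyl in place of 5-methyl-1,3-oxazol-2-yl on a saturated chain carbon bound to an oxygen on an aromatic ring is what it amounts to. Going by the values given here, one measured step bears on it: an at least 21-fold higher number from compound 1 to compound 2 (1.33 log units; beyond the scatter) came with 5-methyl-1,3-oxazol-2-yl taking the place of 3-(benzylamino)propyl. Compound 4 gives up that same ring, so its number is expected to fall back toward compound 1 with 4590 nM as a guide, although the end groups of the two differ. Expected here is an at least 10-fold lower number from compound 2 to compound 4 (1.00 log units; beyond the scatter) as a large move toward stronger inhibition. The estimate for compound 4 is 10000 nM with an expected range from 3000 nM to 40000 nM around it.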

Compound 4, half-maximal inhibitory concentration: 9900 nM
Estimate against measurement, compound 4: 1.0-fold (0.00 log units) above; the range from low to high includes it.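

Putting 2-(4-methylpiperazin-1-yl)ethyl in place of 5-methyl-1,3-oxazol-2-yl at this place gives an at least 10-fold lower number from compound 2 to compound 4 (1.00 log units; beyond the scatter) in this assay, so a chain ending in a piperazine ring brings back a measurable value. Going by these compounds, the true size of that step is unknown, as the entry for compound 2 is a limit and not a number: the limit of > 100000 nM in this assay, at which 1 of the 4 values shown sits. Set against the benzylamino chain, the 4-methylpiperazin-1-yl end gives a 2.2-fold higher number from compound 1 to compound 4 (0.33 log units; beyond the scatter), so two different amine ends both give measurable values here, the benzylamino end the lower one.

On these data alone, whether a chain ending in a morpholine ring or a primary amine would behave like compound 1 or compound 4 remains open. So does the effect of a longer chain carrying the same 4-methylpiperazin-1-yl end.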